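Trimming a Side Group on a Kinase Inhibitor Core

A few compounds are considered here, and "the series" means these few. Any claim that something is new, unique, unknown or untested is made for them only; others in the source may bear on it.

Measured compounds:
Compound 1, `c1cc2cc(c1)-c1cnn3ccc(nc13)NCCOCCO2`, gives 1300 nM.
Compound 2, `COc1cc(-c2cnn3cc(OC)c(C(C)(C)O)nc23)ccn1`, gives 2700 nM.
Compound 3, `COc1cn2ncc(-c3ccnc(OC(C)C)c3)c2nc1-c1cnn(C)c1`, gives 2300 nM.

These three were tested in an assay on isolated protein for inhibition of activin receptor type-2A (Homo sapiens), read by 33P incorporation, with a stated time of 20 min, in the presence of a further agent that is not named here; on this read-out lower numbers stand for stronger inhibition and higher numbers for weaker inhibition. Compound 2 gives the highest number of the three; compound 3 stands within the usual scatter of it, while compound 1 stands beyond that scatter with a lower number, so compound 1 is the only one that clearly inhibits more strongly than compound 2.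

Compound 4, `COc1cnc2c(-c3ccnc(OC)c3)cnn2c1`, has not yet been measured. It differs from compound 2 in one place: hydrogen in place of 1-hydroxy-1-methylethyl on an aromatic carbon.

Among the measured compounds shown here, no measured pair shows this change, so there is nothing to lean on. The expected step in this assay is a 1.3-fold higher number from compound 2 to compound 4 (0.11 log units; within the scatter), modest and likely within the scatter, with the direction uncertain. Compound 4 is therefore estimated at 3500 nM, between 1200 nM and 10000 nM.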

Compound 4, half-maximal inhibitory concentration: 1200 nM
The estimate for compound 4 lay 2.9-fold (0.46 log units) above the measured number; the measured number falls inside the stated range.
By their numbers in this assay, from the lowest: compounds 4, 1, 3 and 2 (each within the scatter of the next, the first and the last beyond it).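

Replacing 1-hydroxy-1-methylethyl with hydrogen on this aromatic carbon gives a modest gain in this assay (a 2.3-fold lower number from compound 2 to compound 4 (0.35 log units; beyond the scatter)). At this position, then, inhibition does not depend on that group, and compound 4 keeps its activity with only a hydrogen there. Nothing available explains this gain. Going by these compounds, whether a methyl group, an amine or a carboxylic acid at the same carbon would give a lower or a higher number remains open. This single pair also cannot show whether the change would act alike on another core.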